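This account rests on a few compounds, and the source may have more. Where it says the series, first, only, none or still open, it means among the compounds named here.

In a functional assay on RAW264.7 cells (Mus musculus) for inhibition, read by ELISA, with a stated time of 24 h (on this read-out higher numbers stand for an effect only at larger amounts of compound and lower numbers for an effect already at smaller amounts), compound 1 `CC/C=C\C[C@H]1C(=O)C=C[C@H]1CC(=O)OCCCCC` gives 25000 nM while compound 2 `CC/C=C\C[C@H]1C(=O)C=C[C@H]1CC(=O)Oc1ccccc1` gives 33000 nM and compound 3 `CC/C=C\C[C@H]1C(=O)C=C[C@H]1CC(=O)OCCOCCO` gives 36000 nM with the same core throughout. Compound 3 thus stands level with the other two, its value lying within the scatter of both. Compound 4 `CC/C=C\C[C@H]1C(=O)C=C[C@H]1CC(=O)OC(C)CC` differs from it by sec-butyl in place of 2-(2-hydroxyethoxy)ethyl on an oxygen next to a carbonyl group. The measured steps that bear on this change are a 1.3-fold higher number from compound 1 to compound 2 (0.12 log units; within the scatter) and a 1.4-fold higher number from compound 1 to compound 3 (0.16 log units; within the scatter) and a 1.1-fold higher number from compound 2 to compound 3 (0.04 log units; within the scatter) and each of them alters the same part of the molecule without leaving the scatter. No step beyond the scatter is therefore expected in this assay for this exchange, and no direction can be argued from these data. The expected step is only a 1.2-fold lower number from compound 3 to compound 4 (0.08 log units; within the scatter) and it remains a small one. Compound 4 is expected at an estimated 30000 nM with a likely range from 16000 nM to 55000 nM in this test.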

Compound 4, half-maximal effective concentration: 22000 nM
The estimate for compound 4 lay 1.4-fold (0.13 log units) above the measured number; the range from low to high includes it.
By their numbers in this assay, from the lowest: compounds 4, 1, 2 and 3 (each within the scatter of the next).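

In this assay, sec-butyl on an oxygen next to a carbonyl group gives no separation from any of the earlier groups, with a 1.6-fold lower number from compound 3 to compound 4 (0.21 log units; within the scatter), a 1.5-fold lower number from compound 2 to compound 4 (0.18 log units; within the scatter) and a 1.1-fold lower number from compound 1 to compound 4 (0.06 log units; within the scatter). The first of these steps is the most telling: the hydrogen-bond donor and acceptors of 2-(2-hydroxyethoxy)ethyl are absent from sec-butyl, yet the step stays within the scatter, so across these four compounds the groups at this place cannot be told apart. Nothing available explains this flat result.

On these data alone, whether a group bearing an amine or a carboxylic acid at this place would move the number beyond the scatter remains open. So does the effect of any change to the shared core, which is the same in all four compounds.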